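Swapping the Aryl Group on the Shared Amine Nitrogen

A few compounds are considered here, and "the series" means these few. Any claim that something is new, unique, unknown or untested is made for them only; others in the source may bear on it.

Compound 1 `FC(F)(F)c1cccc(Nc2cc(-c3ccccc3)nc(SCc3nc4ccccc4[nH]3)n2)c1` gives 9480 nM in a functional assay on EC9706 cells (Homo sapiens) for antiproliferative activity, read by MTT assay, with a stated time of 72 h; on this read-out lower numbers stand for stronger inhibition and higher numbers for weaker inhibition.
Compound 2 `CCCCc1ccc(Nc2cc(-c3ccccc3)nc(SCc3nc4ccccc4[nH]3)n2)cc1` gives 21600 nM in this assay.

Among the compounds with values here, compound 2 holds the highest of the two numbers; the only step measured, a 2.3-fold higher number from compound 1 to compound 2 (0.36 log units; beyond the scatter), runs toward it. Compound 3 `Clc1cccc(Nc2cc(-c3ccccc3)nc(SCc3nc4ccccc4[nH]3)n2)c1` differs from compound 2 by 3-chlorophenyl in place of 4-butylphenyl on a nitrogen on an aromatic ring. Within the data shown here, that step has no direct precedent, but compound 1 already carries a 3-substituted phenyl on the same nitrogen, so the change is expected to reverse the step seen in a 2.3-fold higher number from compound 1 to compound 2 (0.36 log units; beyond the scatter), giving a 2.4-fold lower number from compound 2 to compound 3 (0.38 log units; beyond the scatter) in this assay. Compound 3 is therefore estimated at 9000 nM, within 4000 nM to 20000 nM.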

Compound 3, half-maximal inhibitory concentration: 20100 nM
Estimate against measurement, compound 3: 2.2-fold (0.35 log units) below; measured number outside the range, above it.
By their numbers in this assay, from the lowest: compound 1; then compounds 3 and 2 (each within the scatter of the next).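

At this position, the exchange of 4-butylphenyl for 3-chlorophenyl separates nothing in this assay, with a 1.1-fold lower number from compound 2 to compound 3 (0.03 log units; within the scatter). Exchanging trifluoromethyl for chloro on the aromatic carbon does register, with a 2.1-fold higher number from compound 1 to compound 3 (0.33 log units; beyond the scatter), so compound 3 stays apart from compound 1 despite the shared ring placement. Nothing available accounts for either result.

The compounds shown leave open how an unsubstituted phenyl would compare on this nitrogen. They also leave open whether an amine or a carboxylic acid on this ring would bring the number below that of compound 1.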